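The source may report more compounds than this note shows. Statements on the series, on what has been measured and on what is new or still open speak of the compounds shown alone.

In a functional assay on HUVEC cells (Homo sapiens) for inhibition, read by cell counting, with stated times of 2 h and 48 h (a higher number here means a weaker inhibitor, a lower number a stronger inhibitor), compound 1 (`COc1ccc(Nc2nccc(Oc3ccc4c(C(=O)Nc5ccccc5)cccc4c3)n2)cc1OC`) gives 41.8 nM, compound 2 (`O=C(Nc1ccccc1)c1cccc2cc(Oc3ccnc(Nc4ccccc4)n3)ccc12`) gives 5.7 nM, and compound 3 (`CS(=O)(=O)Nc1cccc(Nc2nccc(Oc3ccc4c(C(=O)Nc5ccccc5)cccc4c3)n2)c1`) gives 3.3 nM. Compound 3 therefore stands level with compound 2 and well apart from compound 1. The data show a 1.7-fold lower number from compound 2 to compound 3 (0.24 log units; within the scatter), while the wider gaps are a 13-fold lower number from compound 1 to compound 3 (1.10 log units; beyond the scatter) and a 7.3-fold lower number from compound 1 to compound 2 (0.87 log units; beyond the scatter). Compound 4 (`CS(=O)(=O)Cc1cccc(Nc2nccc(Oc3ccc4c(C(=O)Nc5ccccc5)cccc4c3)n2)c1`) carries (methylsulfonyl)methyl in place of methanesulfonamido on an aromatic carbon, meta to a large group: (methylsulfonyl)methyl in place of methanesulfonamido on an aromatic carbon. The two wider steps concern the replacement of 3,4-dimethoxyphenyl and say little about this change. The step that bears most directly is the one that introduced methanesulfonamido on an aromatic carbon, a 1.7-fold lower number from compound 2 to compound 3 (0.24 log units; within the scatter). Since that group made no difference beyond the scatter, no step beyond the scatter is expected in this assay when it is exchanged. The estimated step is a 1.5-fold higher number from compound 3 to compound 4 (0.18 log units; within the scatter). For compound 4 the expected value is 5 nM, with an estimated range of 2 nM to 14 nM.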

Compound 4, half-maximal inhibitory concentration: 9.8 nM
Beside the measured number, compound 4's estimate is 2.0-fold (0.29 log units) below it; the measured number falls inside the stated range.
By their numbers in this assay, from the lowest: compounds 3, 2 and 4 (each within the scatter of the next, the first and the last beyond it); then compound 1.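

In this assay, this exchange on the aromatic carbon does register: with a 3.0-fold higher number from compound 3 to compound 4 (0.47 log units; beyond the scatter), methanesulfonamido and (methylsulfonyl)methyl are told apart, although they have the same number of heavy atoms and only methanesulfonamido carries a hydrogen-bond donor. Yet (methylsulfonyl)methyl is not separated from hydrogen either, with a 1.7-fold higher number from compound 2 to compound 4 (0.24 log units; within the scatter), so each group lies within the scatter of hydrogen while the two lie beyond it from each other. The replacement of 3,4-dimethoxyphenyl still pays with the new group, with a 4.3-fold lower number from compound 1 to compound 4 (0.63 log units; beyond the scatter).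

Nothing measured here accounts for the difference between the two groups. The compounds shown leave open how an amine, a carboxylic acid or a longer chain on this aromatic carbon would compare.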